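Hydroxymethyl in place of hydroxy in compound 3

This account rests on a few compounds, and the source may have more. Where it says the series, first, only, none or still open, it means among the compounds named here.

In a functional assay on MCF7 cells (Homo sapiens) for antiproliferative activity, read by MTT assay, with a stated time of 72 h (on this read-out higher numbers stand for weaker inhibition and lower numbers for stronger inhibition), compound 1 `COc1cc2c(Nc3ccc(C#N)cc3)ncnc2cc1OCCCN(C)C` gives 45000 nM. Compound 2 `COc1cc2c(Nc3ccc(C#N)cc3)ncnc2cc1OCCCN1CCC(O)CC1` gives > 100000 nM, which is a limit of the assay and not a number. Compound 3 `COc1cc2c(Nc3ccc(C#N)cc3)ncnc2cc1OCCCN1CCC(CO)CC1` carries hydroxymethyl in place of hydroxy on a saturated ring carbon, (hydroxymethyl in place of hydroxy on a saturated ring carbon). For the measured compounds named here, one measured step bears on this change: an at least 2.2-fold higher number from compound 1 to compound 2 (0.34 log units; beyond the scatter). That step put 4-hydroxypiperidin-1-yl in place of dimethylamino, and compound 3 alters that same group. Going by the values given here, it lies beyond the scatter, but it is a different exchange, and no measured step covers hydroxy against hydroxymethyl. No change beyond the scatter is therefore expected in this assay. The expected step is an at least 1.2-fold lower number from compound 2 to compound 3 (0.09 log units; that floor lies within the scatter). For compound 3 the estimated value is 80000 nM, with an expected range from 30000 nM to 100000 nM.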

Compound 3, half-maximal inhibitory concentration: 35100 nM
Compound 3: the middle estimate sits 2.3-fold (0.36 log units) above what was measured; the measured number falls inside the stated range.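

In this assay, hydroxymethyl in place of hydroxy on the saturated ring carbon gives an at least 2.8-fold lower number from compound 2 to compound 3 (0.45 log units; beyond the scatter), so the group at this place does bear on the read-out. Going by these compounds, the full size of that step stays open, since compound 2 stands at a limit of the assay and not at a number: the limit of > 100000 nM in this assay, at which 1 of the 3 values shown sits. Set against dimethylamino, 4-(hydroxymethyl)piperidin-1-yl gives a 1.3-fold lower number from compound 1 to compound 3 (0.11 log units; within the scatter), which lies within the scatter, so the loss seen with 4-hydroxypiperidin-1-yl does not carry over to this group.

On these data alone, whether 2-hydroxyethyl, methoxymethyl or aminomethyl on the same ring carbon would hold the number or shift it remains open. As far as these compounds go, it is also open whether the hydroxy to hydroxymethyl step would read the same with a group other than the nitrile on the shared core.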